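Swapping methyl for isopropyl on an exocyclic amine

The compounds below may be only part of what the source reports. "The series", "measured", "known", "first", "only" and "open" are said of these compounds alone.

For the measured compounds named here, compound 1, `CNc1nc(NCc2ccccc2)nc2ccccc12`, is the one compound here with a number: in an ADME assay on J774.A1 cells (Mus musculus) for inhibition, read by MTT assay, with a stated time of 72 h (a lower number here means that less compound is needed, a higher number that more compound is needed for the effect), compound 1 gives 15000 nM. Going by the values given here, compound 2, `CNc1nc(NCCO)nc2ccccc12`, was tested in this assay but compound 2 has only the entry "not determined" (no result reported) with no result reported, so compound 1 stands alone and no comparison between measured compounds is available. Compound 3, `CC(C)Nc1nc(NCc2ccccc2)nc2ccccc12`, differs from compound 1 in a single place: isopropyl in place of methyl on a nitrogen on an aromatic ring. The change adds carbon to the amino group on the shared core and touches no donor, acceptor or charge. Among the compounds with values here, with no measured step of this kind to lean on, the step is expected to be small, likely within the usual scatter, and the estimated step from compound 1 to compound 3 is a 1.3-fold lower number from compound 1 to compound 3 (0.10 log units; within the scatter). Compound 3 is therefore expected to give about 12000 nM in this assay, with a range from 4000 nM to 40000 nM.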

Compound 3, half-maximal effective concentration: 7200 nM
Estimate against measurement, compound 3: 1.7-fold (0.22 log units) above; the range from low to high includes it.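

In this assay, the change at this nitrogen gives the first readable step, a 2.1-fold lower number from compound 1 to compound 3 (0.32 log units; beyond the scatter), so the amino group on the shared core is a place where a small change in the alkyl group can register just beyond ordinary measurement noise. The direction is also now known: going from methyl to isopropyl, with more carbon and no added donor, acceptor or charge, lowers the number rather than raising it, although this rests on one modest step from a single pair. Nothing available here explains why the number falls.

Going by these compounds, whether a longer chain such as n-butyl, or a ring such as cyclohexyl, on the same nitrogen would lower the number further remains open. So does whether the isopropyl swap would act the same way with the 2-hydroxyethyl group of compound 2 in place of benzyl, since compound 2 has no result to compare.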